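Moving from 4-methylphenyl to 3-bromophenyl in compound 3

The source may report more compounds than this note shows. Statements on the series, on what has been measured and on what is new or still open speak of the compounds shown alone.

Three compounds sharing a closely related core have numbers in a functional assay on SK-MEL-28 cells (Homo sapiens) for cytotoxicity, read by CCK-8 assay, with a stated time of 24 h; on this read-out higher numbers stand for weaker inhibition and lower numbers for stronger inhibition. Compound 2 `COc1ccccc1Oc1c(N)nc(Cc2ccccc2)nc1OCCO` gives 14000 nM, compound 3 `COc1ccccc1Oc1c(N)nc(-c2ccc(C)cc2)nc1OCCO` gives 6190 nM and compound 1 `COc1ccccc1Oc1c(N)nc(-c2ccc(I)cc2)nc1Cl` gives 1250 nM. Compound 3 therefore has the second highest of the three numbers, with a clear gap to each of the others.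

Compound 4 `COc1ccccc1Oc1c(N)nc(-c2cccc(Br)c2)nc1OCCO` keeps the 2-hydroxyethoxy group of compound 3 but carries 3-bromophenyl in place of 4-methylphenyl, on the aromatic carbon between two ring nitrogen atoms: 3-bromophenyl in place of 4-methylphenyl on an aromatic carbon.

Among the measured compounds shown here, only one measured step changes this same place: a 2.3-fold lower number from compound 2 to compound 3 (0.35 log units; beyond the scatter). That step is modest, though beyond the scatter, and it replaces benzyl rather than exchanging one substituted phenyl for another. Compound 1 has the lowest number, but it differs from compound 3 in more than one place, so its gap cannot be read as the effect of the aryl group alone. For the measured compounds named here, no measured pair shows what a bromine on this phenyl does. A small change is therefore the most reasonable expectation, and the estimated step is a 1.2-fold lower number from compound 3 to compound 4 (0.09 log units; within the scatter), not expected to exceed the scatter. For compound 4 the expected value is 5000 nM, with an estimated range of 2000 nM to 12000 nM.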

Compound 4, half-maximal inhibitory concentration: 4040 nM
For compound 4 the middle estimate is 1.2-fold (0.09 log units) above the measured one; the range from low to high includes it.
By their numbers in this assay, from the lowest: compound 1; then compounds 4 and 3 (each within the scatter of the next); then compound 2.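

In this assay, the step from 4-methylphenyl to 3-bromophenyl gives a 1.5-fold lower number from compound 3 to compound 4 (0.19 log units; within the scatter), so this exchange on the aromatic carbon between two ring nitrogen atoms does not separate the two substituted phenyl groups, even though one carries a bromine and the other a methyl. Against benzyl, the new compound shows a 3.5-fold lower number from compound 2 to compound 4 (0.54 log units; beyond the scatter), which means that both substituted phenyl groups now measured at this place, in compound 3 and compound 4, give numbers clearly lower than the one for compound 2. Nothing in the data given explains these numbers or says why the two phenyl groups read alike here.

The single step from compound 3 to compound 4 changes the identity of the substituent and its place on the phenyl together, so the compounds shown do not tell the contribution of either change alone. They also leave open whether an amine or a carboxylic acid on this phenyl would stay within the same narrow band in this assay or move clearly away from it.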